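Amine substituent and tolerated concentration in the butoxyphenyl series

The source may report more compounds than this note shows. Statements on the series, on what has been measured and on what is new or still open speak of the compounds shown alone.

Compound 1 `CCCCOc1ccc(-c2nc3ncccn3c2NC2CCCC2)cc1` stands lowest of the two numbers shown; in a toxicity assay on A549 cells (Homo sapiens) for cytotoxicity, read by luminescence and CellTiter-Glo, with a stated time of 48 h (a lower number here means that less compound is tolerated, a higher number that more compound is tolerated), compound 1 gives 40000 nM. Its nearest neighbour, compound 3 `CCCCOc1ccc(-c2nc3ncccn3c2Nc2ccccc2)cc1`, gives 100000 nM. Compound 2 `CCCCOc1ccc(-c2nc3ncccn3c2N)cc1` reaches only a limit of the assay, > 100000 nM. The two measured changes at this position both move the number upward: an at least 2.5-fold higher number from compound 1 to compound 2 (0.39 log units; beyond the scatter) and a 2.5-fold higher number from compound 1 to compound 3 (0.40 log units; beyond the scatter). Compound 4 `CCCCOc1ccc(-c2nc3ncccn3c2NCc2ccccn2)cc1` differs from compound 1 by (pyridin-2-yl)methyl in place of cyclopentyl on a nitrogen on an aromatic ring. Both earlier replacements of cyclopentyl raised the number by a modest step, so a step of similar size and direction is expected here, a 2.0-fold higher number from compound 1 to compound 4 (0.30 log units; within the scatter), with a fair chance that the result sits at the limit of > 100000 nM in this assay, at which 1 of the 3 values shown sits. Compound 4 is therefore estimated at 80000 nM, ranging from 30000 nM to 200000 nM.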

Compound 4, half-maximal cytotoxic concentration: > 100000 nM
Compound 4: only a limit was reported (the forecaster's own chance of this, stated with the estimate: 40%); middle value at least 1.2-fold (0.09 log units) from the limit.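

With (pyridin-2-yl)methyl in place of cyclopentyl on this nitrogen, the step is an at least 2.5-fold higher number from compound 1 to compound 4 (0.39 log units; beyond the scatter). This third replacement moves the number the same way, now with a ring carrying a hetero atom. Compound 4 gives > 100000 nM, which is a limit of the assay. The top of the measurable range now holds a second compound: the limit of > 100000 nM in this assay, at which 2 of the 4 values shown sit.

With (pyridin-2-yl)methyl in place of phenyl, the step is a number no lower from compound 3 to compound 4 (the limit leaves the size open). The step from compound 2 to compound 4 cannot be read, so the order among these compounds stays open. Also open, from the compounds shown here alone, is whether cyclohexyl or a butyl chain on this nitrogen would lower the number as cyclopentyl does.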